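A few compounds are considered here, and "the series" means these few. Any claim that something is new, unique, unknown or untested is made for them only; others in the source may bear on it.

Measured so far in an ADME assay on RAW264.7 cells (Mus musculus) for cytotoxicity, read by resazurin assay, with a stated time of 48 h; a higher number here means that more compound is tolerated, a lower number that less compound is tolerated:

compound 1 `CC(C)(C)OC(=O)NCCCCNCCCN(Cc1ccccc1)Cc1ccccc1`: 12500 nM
compound 2 `CC(C)(C)OC(=O)NCCCCNCCCN(Cc1ccc(OCc2ccccc2)cc1)Cc1ccc(OCc2ccccc2)cc1`: 33300 nM
compound 3 `CC(C)(C)OC(=O)NCCCCNCCCN(Cc1cccc(-c2ccccc2)c1)Cc1cccc(-c2ccccc2)c1`: > 100000 nM

The value of compound 3 is a limit of this assay and not a number (the limit of > 100000 nM in this assay, at which 1 of the 3 values shown sits). Of the two numbers that remain, compound 2 stands highest, so more of it is tolerated than of compound 1, whose number is the nearest and lower one; that gap lies beyond the scatter.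

Compound 4 `NCCCCNCCCN(Cc1ccc(OCc2ccccc2)cc1)Cc1ccc(OCc2ccccc2)cc1` has not yet been measured in this assay. It differs from compound 2 in one place: hydrogen in place of tert-butoxycarbonyl on an amine nitrogen. Within the data shown here, no pair of measured compounds shows the same change, so there is no measured precedent for its size or direction.

The step from compound 2 to compound 4 is expected to be a 1.7-fold lower number from compound 2 to compound 4 (0.22 log units; within the scatter), a small lowering that may well sit within the scatter. For compound 4 the value expected in this assay is 20000 nM, with a range from 6000 nM to 60000 nM.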

Compound 4, half-maximal cytotoxic concentration: > 100000 nM
Compound 4: a limit, no number (the forecaster's own chance of this, stated with the estimate: 10%); middle value at least 5.0-fold (0.69 log units) from the limit.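

Hydrogen in place of tert-butoxycarbonyl on an amine nitrogen gives the only measured step at this position in this assay: an at least 3.0-fold higher number from compound 2 to compound 4 (0.47 log units; beyond the scatter), so more of compound 4 is tolerated than of compound 2. Compound 4 reads > 100000 nM, which is a limit of the assay and not a number. The step therefore fixes a direction and a minimum size, but no full size: the limit of > 100000 nM in this assay, at which 2 of the 4 values shown sit.

Still open, on these data alone, is whether an acetyl or a methyl group on that amine nitrogen would give a number nearer compound 2 or compound 4. Also open, as far as these compounds go, is how far the same change from tert-butoxycarbonyl to hydrogen would move the number on the core of compound 1.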